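Notes on nitrogen substitution of the shared core

This account rests on a few compounds, and the source may have more. Where it says the series, first, only, none or still open, it means among the compounds named here.

Compound 1 `O=C1c2c[n+]([O-])c3ccccc3c2C(=O)c2[nH]c3ccccc3c21` is the member of the set with hydrogen on the aromatic nitrogen of the shared core. In a toxicity assay on HEK-293T cells (Homo sapiens) for cytotoxicity, read by MTT assay, with a stated time of 72 h (on this read-out lower numbers stand for stronger inhibition and higher numbers for weaker inhibition), compound 1 gives 890 nM, the second highest of the three numbers: compound 2 `CC1(C)OC[C@@H](Cn2cc(Cn3c4c(c5ccccc53)C(=O)c3c[n+]([O-])c5ccccc5c3C4=O)nn2)O1` gives 6020 nM, a higher number, and compound 3 `CC1(C)OC[C@H](Cn2cc(Cn3c4c(c5ccccc53)C(=O)c3c[n+]([O-])c5ccccc5c3C4=O)nn2)O1` gives 100 nM, a lower number. Compounds 2 and 3 carry the same group on that nitrogen, and the step of a 60-fold lower number from compound 2 to compound 3 (1.78 log units; beyond the scatter) rests on the fact that compounds 2 and 3 differ only in the configuration as drawn alone. Their two values show that a substituent on the nitrogen can leave the number on either side of compound 1, and that configuration alone spans a wider interval than the gap from compound 1 to either of them.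

Compound 4 `O=C1c2c[n+]([O-])c3ccccc3c2C(=O)c2c1c1ccccc1n2CCCCn1ccnc1` differs from compound 1 by 4-(1H-imidazol-1-yl)butyl in place of hydrogen on an aromatic nitrogen. Going by the values given here, no measured step follows exactly this change; the only measured step, between compound 2 and compound 3, concerns configuration and not the presence of a substituent. The values of compounds 2 and 3 mark the interval within which a nitrogen substituent has so far placed the number. The estimate for compound 4 is therefore expected to amount to a step of a 1.1-fold lower number from compound 1 to compound 4 (0.05 log units; within the scatter), with no direction favoured beyond the scatter. In this assay compound 4 is expected to give about 800 nM, within 150 nM to 5000 nM.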

Compound 4, half-maximal inhibitory concentration: 280 nM
The estimate for compound 4 lay 2.9-fold (0.46 log units) above the measured number; low and high end bracket the measured number.
By their numbers in this assay, from the lowest: compound 3; then compound 4; then compound 1; then compound 2.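

In this assay, going by these compounds alone, 4-(1H-imidazol-1-yl)butyl in place of hydrogen on the aromatic nitrogen gives a 3.2-fold lower number from compound 1 to compound 4 (0.50 log units; beyond the scatter) as the first measured step in the set that concerns the presence of a substituent at this position and not its configuration. The step is modest but beyond the scatter, so this nitrogen can carry a chain ending in a five-membered aromatic ring with a lower number than compound 1 shows with hydrogen in the same place. Nothing at hand gives a cause for this step.

The compounds shown do not separate the contribution of the butyl chain from that of the imidazole at its end: a plain butyl group, a shorter or longer chain bearing the same imidazole, or an amine or a carboxylic acid in place of the imidazole would be needed to tell these apart. Only this one cytotoxicity read-out on a single cell line is shown, so whether the lower number for compound 4 carries over to any other cell line or assay remains open.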